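Swapping the Isopropyl for an Acetyl on the Phenyl Ring

The source may hold more compounds than are shown below. What is called first, only, known or untested is meant among the compounds shown, and "the series" means these compounds.

Of the compounds shown here, three built on one shared core have been tested in an ADME assay on MT4 cells (Homo sapiens) for cytotoxicity, read by MTT assay; on this read-out lower numbers stand for higher toxicity in this test and higher numbers for lower toxicity in this test. Compound 1 `S=C(Nc1ccccc1)OCCc1ccccn1` reaches only a limit of the test, at > 100000 nM. Compound 2 `O=[N+]([O-])c1cccc(NC(=S)OCCc2ccccn2)c1` gives 100000 nM, and compound 3 `CC(C)c1ccc(NC(=S)OCCc2ccccn2)cc1` gives 45000 nM. Of the two plain numbers, compound 3 stands lowest, and the nearest one, that of compound 2, lies beyond the usual scatter above it (the limit of > 100000 nM in this assay, at which 1 of the 3 values shown sits).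

Compound 4 `CC(=O)c1ccc(NC(=S)OCCc2ccccn2)cc1` is not yet measured. It differs from compound 3 by one change: acetyl in place of isopropyl on an aromatic carbon. Two measured steps start from compound 1 and show what a group on that ring can do. Putting an isopropyl in place of hydrogen gave an at least 2.2-fold lower number from compound 1 to compound 3 (0.34 log units; beyond the scatter), while putting a nitro in place of hydrogen gave a number no higher from compound 1 to compound 2 (the limit leaves the size open). Within the data shown here, no measured step places an acetyl, so the isopropyl step is the one that bears most directly, and compound 4 removes that isopropyl. The number for compound 4 is therefore expected to move back up toward the values of compound 1 and compound 2, a step of a 1.8-fold higher number from compound 3 to compound 4 (0.25 log units; within the scatter). The estimate for compound 4 in this assay is 80000 nM, with a likely range from 35000 nM to 200000 nM.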

Compound 4, half-maximal cytotoxic concentration: >= 100000 nM
Compound 4 gave a limit, no number; the forecaster's own chance of this, stated with the estimate: 30%; middle value at least 1.2-fold (0.09 log units) from the limit.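

In this assay, acetyl in place of isopropyl at this spot, para to a large group, gives an at least 2.2-fold higher number from compound 3 to compound 4 (0.34 log units; beyond the scatter). The lower number of compound 3 therefore does not survive this exchange, although both groups have 3 heavy atoms and differ in that acetyl brings an oxygen, a double bond outside the aromatic ring and a hydrogen-bond acceptor. The full size of the step stays open and the step linking compound 1 to compound 4 cannot be read at all, because compound 4 gives a limit and not a number: the limit of >= 100000 nM in this assay, at which 1 of the 4 values shown sits.

Going by these compounds, it remains open whether the lower number of compound 3 belongs to isopropyl alone or would also come with a tert-butyl group or a longer carbon chain on the same ring carbon. On these data alone, it is equally open whether the number stays high with other groups that carry oxygen or nitrogen there, such as a methoxy group, an amine or a carboxylic acid.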